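This account rests on a few compounds, and the source may have more. Where it says the series, first, only, none or still open, it means among the compounds named here.

Working notes on the series in a functional assay on A549 cells (Homo sapiens) for cytotoxicity, read by MTT assay, with a stated time of 4 days; a higher number here means a weaker inhibitor, a lower number a stronger inhibitor.

Compound 1 `C=C1C(=O)[C@]23C[C@@]1(O)CC[C@H]2c1ccc(O)c(C)c1[C@@H]3Cn1cc(-c2ccccn2)nn1` and compound 2 `C=C1C(=O)[C@]23C[C@@]1(O)CC[C@H]2c1ccc(O)c(C)c1[C@@H]3Cn1cc(-c2ccc(C(F)(F)F)cc2)nn1` share one core and differ only in the group on the triazole carbon: 4-(trifluoromethyl)phenyl in place of pyridin-2-yl on an aromatic carbon. In this assay compound 1 gives 1570 nM, and compound 2 gives 1110 nM; the step of a 1.4-fold lower number from compound 1 to compound 2 (0.15 log units; within the scatter) is within the scatter of the method, so the two values are not distinguishable.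

Compound 3 `C=C1C[C@]23C[C@@]1(O)CC[C@H]2c1cc(Br)c(O)c(C)c1[C@@H]3Cn1cc(-c2ccccn2)nn1` carries a different core from compound 1, and the difference between the two cores is not broken down here. In this assay compound 3 gives only a limit, > 20000 nM; this is the limit (the limit of > 20000 nM in this assay, at which 1 of the 3 values shown sits), at which the value sits without a number.

Compound 4 `C=C1C[C@]23C[C@@]1(O)CC[C@H]2c1cc(Br)c(O)c(C)c1[C@@H]3Cn1cc(-c2ccc(C(F)(F)F)cc2)nn1` is not yet measured. It stands to compound 3 as compound 2 stands to compound 1, the same change at the same place: 4-(trifluoromethyl)phenyl in place of pyridin-2-yl on an aromatic carbon. The expected step is a step that the limit leaves unreadable from compound 3 to compound 4, a small one, because the measured step of a 1.4-fold lower number from compound 1 to compound 2 (0.15 log units; within the scatter) lies within the scatter. Compound 4 is accordingly expected to sit at or near the limit where compound 3 stands, and is estimated at 25000 nM, with a likely range from 10000 nM to 60000 nM.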

Compound 4, half-maximal inhibitory concentration: 9280 nM
For compound 4 the middle estimate is 2.7-fold (0.43 log units) above the measured one; measured number below the stated range.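

On the core of compound 3, 4-(trifluoromethyl)phenyl in place of pyridin-2-yl on an aromatic carbon gives an at least 2.1-fold lower number from compound 3 to compound 4 (0.33 log units; beyond the scatter) in this assay, a step beyond the scatter, whereas the same change on the core of compound 1 stays within it. This does not show that the change behaves differently on the two cores: the same change on two cores in this assay, a 1.4-fold lower number (0.15 log units; within the scatter) from compound 1 to compound 2 and an at least 2.1-fold lower number (0.33 log units; beyond the scatter) from compound 3 to compound 4; the limit leaves it open whether they differ

In this assay compound 3 gives > 20000 nM, which is a limit and not a number, so the step on this core has no fixed size: the limit of > 20000 nM in this assay, at which 1 of the 4 values shown sits.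

The compounds shown test only these two groups at this place, each on two cores, so the result rests on a single pair per core and cannot be generalised across the series. Still open, as far as these compounds go, is how other groups on the same aromatic carbon would read in this assay, for example a phenyl ring carrying an amine or a carboxylic acid, and which of the differences between the two cores matter.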